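The source may report more compounds than this note shows. Statements on the series, on what has been measured and on what is new or still open speak of the compounds shown alone.

Measured compounds, inhibition in a functional assay on the whole organism (strain Kunming) for inhibition, with Mus musculus as the target, in the writhing test, at a dose of 40 mg/kg by the oral route; a lower number here means less inhibition, a higher number more inhibition at the dose given (going by the name of the read-out):
compound 1, `CNC(=O)c1cc(-c2ccc(F)cc2F)ccc1OC(C)=O`, 29.9%
compound 2, `CC(=O)Oc1ccc(-c2ccc(F)cc2F)cc1C(=O)NC1CCCCC1`, 15.6%
compound 3, `CC(=O)Oc1ccc(-c2ccc(F)cc2F)cc1C(=O)Nc1ccccc1`, 8.9%

Compound 3 stands lowest of the three numbers in this assay. The step of a number 21 percentage points lower from compound 1 to compound 3 (beyond the scatter) is beyond the scatter, while the step of a number 6.7 percentage points lower from compound 2 to compound 3 (within the scatter) is within it, so compound 3 is separated from compound 1 but not from compound 2.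

Compound 4, `CC(=O)Oc1ccc(-c2ccc(F)cc2F)cc1C(=O)Nc1ccccc1Cl`, is not yet measured. Its difference from compound 3: chloro in place of hydrogen on an aromatic carbon. Within the data shown here, none of the measured steps involves a change of this kind; all three concern the group on the amide-type nitrogen, as in a number 14.3 percentage points lower from compound 1 to compound 2 (beyond the scatter) and a number 21 percentage points lower from compound 1 to compound 3 (beyond the scatter), and the change from cyclohexyl to phenyl there, a number 6.7 percentage points lower from compound 2 to compound 3 (within the scatter), lies within the scatter. The series therefore gives no basis for a step beyond the scatter in this assay on going to compound 4, and none beyond the scatter is expected. Compound 4 is expected to give 10%, with a range from 0% to 25%. The step this estimate means, a number 1.1 percentage points higher from compound 3 to compound 4 (within the scatter), is expected to fall within the scatter.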

Compound 4, a percentage reported as inhibition, in the whole organism at one dose (the size of the read-out at that dose, not a potency): 11.7%
The estimate for compound 4 lay 1.7 percentage points below the measured number; the range from low to high includes it.
By their numbers in this assay, from the lowest: compounds 3, 4 and 2 (each within the scatter of the next); then compound 1.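

In this assay, phenyl to 2-chlorophenyl on the amide-type nitrogen gives a number 2.8 percentage points higher from compound 3 to compound 4 (within the scatter), so this first look at the aromatic ring on that nitrogen shows a chloro ortho to a large group leaving the read-out within the scatter. The same holds against cyclohexyl, with a number 3.9 percentage points lower from compound 2 to compound 4 (within the scatter), while a number 18.2 percentage points lower from compound 1 to compound 4 (beyond the scatter) places a third large group apart from methyl, and among these four compounds none goes against that split. Nothing measured on these compounds speaks to the reason for these results.

Open, going by these compounds, is how an ethyl group or a plain amide with no carbon group on that nitrogen would read, which would show how far the methyl result extends. Also open, on these data alone, is whether a methoxy group or a carboxylic acid in place of the chloro would move the number beyond the scatter.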